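The source may report more compounds than this note shows. Statements on the series, on what has been measured and on what is new or still open speak of the compounds shown alone.

Working notes on the series. Compound 1 `Cc1ccc(COc2ccc(C(=O)NC(=O)Nc3ccc(C)c(-c4nc5ccccc5[nH]4)c3)cc2)cc1` carries a methyl on the ring that bears the benzimidazole and a 4-methylphenyl on the chain carbon bound to the ring oxygen. For the measured compounds named here, in a functional assay on MGC-803 cells (Homo sapiens) for inhibition, read by MTT assay, with a stated time of 48 h (on this read-out lower numbers stand for stronger inhibition and higher numbers for weaker inhibition), compound 1 gives 4250 nM, the lowest of the three numbers measured so far and therefore the strongest inhibitor of the set. Compound 2 `Cc1ccc(NC(=O)NC(=O)c2ccc(OCc3cccc(F)c3)cc2)cc1-c1nc2ccccc2[nH]1` gives 44800 nM in this assay, and compound 3 `Cc1ccc(NC(=O)NC(=O)c2ccc(OCc3ccccc3Cl)cc2)cc1-c1nc2ccccc2[nH]1` gives 19500 nM in this assay. Every measured step alters the group on the chain carbon: an 11-fold higher number from compound 1 to compound 2 (1.02 log units; beyond the scatter), a 4.6-fold higher number from compound 1 to compound 3 (0.66 log units; beyond the scatter) and a 2.3-fold lower number from compound 2 to compound 3 (0.36 log units; beyond the scatter).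

Compound 4 `Cc1ccc(COc2ccc(C(=O)NC(=O)Nc3ccc(Cl)c(-c4nc5ccccc5[nH]4)c3)cc2)cc1` differs from compound 1 at another place: chloro in place of methyl on an aromatic carbon. Going by the values given here, no measured step touches that part of the molecule; all three exchange the 4-methylphenyl, which compound 4 keeps from compound 1. Among the compounds with values here, there is thus no direct precedent for the chloro-for-methyl exchange, and the default expectation is a step that stays within the usual scatter, in either direction. Compound 4 is accordingly expected to give about 4000 nM in this assay, with a range from 1500 nM to 12000 nM. This estimate corresponds to an expected step of a 1.1-fold lower number from compound 1 to compound 4 (0.03 log units; within the scatter).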

Compound 4, half-maximal inhibitory concentration: 3860 nM
Beside the measured number, compound 4's estimate is 1.0-fold (0.02 log units) above it, within the range that was stated.
By their numbers in this assay, from the lowest: compounds 4 and 1 (each within the scatter of the next); then compound 3; then compound 2.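

For the compounds shown here, the exchange of methyl for chloro, on the aromatic carbon ortho to a 1H-benzimidazol-2-yl group and para to a large group, gives a 1.1-fold lower number from compound 1 to compound 4 (0.04 log units; within the scatter) in this assay, and this is the first reading at this position. With the 4-methylphenyl kept on the chain carbon, the two groups at this position cannot be told apart in this read-out, whereas the exchanges on the chain carbon gave an 11-fold higher number from compound 1 to compound 2 (1.02 log units; beyond the scatter) and a 4.6-fold higher number from compound 1 to compound 3 (0.66 log units; beyond the scatter), both beyond the scatter. Going by these compounds alone, the series so far therefore shows one place where a single exchange left the number within the scatter and another where each exchange moved it beyond, but nothing at hand accounts for this difference.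

The compounds shown leave open whether chloro and methyl would also read alike with the 3-fluorophenyl of compound 2 or the 2-chlorophenyl of compound 3 on the chain carbon. They also leave open how this position would respond to a group of another kind, such as a methoxy, an amine or a carboxylic acid.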